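The source may report more compounds than this note shows. Statements on the series, on what has been measured and on what is new or still open speak of the compounds shown alone.

Of the compounds shown here, two have been measured in a functional assay on NCI-H23 cells (Homo sapiens) for antiproliferative activity, with a stated time of 48 h (on this read-out lower numbers stand for stronger inhibition of growth and higher numbers for weaker inhibition of growth), so far. Compound 1 `Cc1cc(O)c(C2=NN(c3ccc(S(N)(=O)=O)cc3)C(c3ccccc3Cl)C2)cc1Cl` gives 1790 nM in this assay. Compound 2 `Cc1cc(O)c(C2=NN(c3ccc(S(N)(=O)=O)cc3)C(/C=C/c3ccccc3)C2)cc1Cl` gives 1680 nM in this assay, so the two numbers sit within the scatter of each other, and compound 2 cannot be set apart from compound 1 on this evidence.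

Compound 3 `COc1ccc(C2CC(c3cc(Cl)c(C)cc3O)=NN2c2ccc(S(N)(=O)=O)cc2)cc1OC` has not been measured. It differs from compound 2 in one place: 3,4-dimethoxyphenyl in place of 2-phenylethenyl on a saturated ring carbon. Going by the values given here, the only measured step at that same saturated ring carbon is a 1.1-fold lower number from compound 1 to compound 2 (0.03 log units; within the scatter), and it stayed within the scatter. That single step gives no sign that swapping the group at this position moves the number far, so for compound 3 the expected step is a 1.0-fold higher number from compound 2 to compound 3 (0.01 log units; within the scatter), essentially none beyond the scatter. Compound 3 is therefore estimated at 1700 nM in this assay, with a range from 700 nM to 4200 nM.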

Compound 3, concentration for 50% growth inhibition: 3110 nM
Compound 3: middle estimate off by 1.8-fold (0.26 log units), on the low side, within the range that was stated.
By their numbers in this assay, from the lowest: compounds 2, 1 and 3 (each within the scatter of the next).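

In this assay, a third group at this saturated ring carbon gives a 1.9-fold higher number from compound 2 to compound 3 (0.27 log units; within the scatter) and a 1.7-fold higher number from compound 1 to compound 3 (0.24 log units; within the scatter), so neither step can be told apart from repeat-measurement noise. The position has now held 2-chlorophenyl, 2-phenylethenyl and 3,4-dimethoxyphenyl, including a group with 2 hydrogen-bond acceptors where 2-phenylethenyl has none, and these numbers do not separate the three compounds. Nothing available here speaks to why the numbers fall as they do. 

From the compounds shown here alone, all three groups carry a six-membered aromatic ring of carbon only, so what an amine, a carboxylic acid or a plain alkyl chain would do at this carbon stays open. Going by these compounds, the 4-sulfamoylphenyl and 5-chloro-2-hydroxy-4-methylphenyl groups are the same in all three compounds, so the effect of changing either also remains unknown.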